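This account rests on a few compounds, and the source may have more. Where it says the series, first, only, none or still open, it means among the compounds named here.

In an ADME assay on microsomes from liver (Rattus norvegicus) for pharmacokinetics (on this read-out higher numbers stand for fast clearance and lower numbers for slow clearance), compound 1 `C[C@@H]1C[C@H]1C(=O)N1CCN(c2nc(-c3cnn(C)c3)ncc2C#N)C[C@H]1C` gives 54 mL/min/kg. Compound 2 `CC1CC1C(=O)N1CCN(c2nc(-c3cnn(C)c3)ncc2C#N)C[C@H]1C` has the same atoms and bonds, and its reading of < 36 mL/min/kg is a limit of the assay, not an exact number. Its true position is therefore unknown, and the limit of < 36 mL/min/kg in this assay, at which 1 of the 2 values shown sits, shows how little of this small set is fully resolved.

Among the compounds with values here, the only measured step is an at least 1.5-fold lower number from compound 1 to compound 2 (0.17 log units; that floor lies within the scatter). It concerns stereochemistry alone, as seen in the fact that one of compounds 1 and 2 is drawn with a defined configuration and the other without, at the place where they differ, so it offers only indirect guidance for a change of group.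

Compound 3 `CCC(=O)N1CCN(c2nc(-c3cnn(C)c3)ncc2C#N)C[C@H]1C` keeps the shared core and differs from compound 2 at one place: ethyl in place of 2-methylcyclopropyl on a carbonyl carbon. In other words, (2-methylcyclopropyl)carbonyl becomes propanoyl.

Within the data shown here, no measured step alters the group on this carbonyl carbon, so the data indicate no direction, and no step beyond the scatter is expected in this assay. The main anchor for this expectation is compound 2, whose reading of < 36 mL/min/kg is a limit. The expected change is a step that the limit leaves unreadable from compound 2 to compound 3. For compound 3, the estimated clearance is 33 mL/min/kg, with an expected range of 18 mL/min/kg to 60 mL/min/kg.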

Compound 3, clearance: < 36 mL/min/kg
Compound 3 was reported as a limit; the forecaster's own chance of this, stated with the estimate: 50%; the middle value does not contradict the limit.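

In this assay compound 3 reads < 36 mL/min/kg, which is a limit of the assay and not an exact number. Within the data shown here, this is the first reading for a change of the group on the carbonyl carbon: the ring of 2-methylcyclopropyl gives way to the open ethyl, and the reading stays at the same limit that compound 2 shows, so the step between these two compounds cannot be read. Against the one exact reading in the set, the result is an at least 1.5-fold lower number from compound 1 to compound 3 (0.17 log units; that floor lies within the scatter), so even this comparison establishes no real change, and little of this small set is fully resolved: the limit of < 36 mL/min/kg in this assay, at which 2 of the 3 values shown sit.

Going by these compounds, how far compound 2 and compound 3 truly lie under that limit stays open, and with it whether the three-membered ring matters at all at this place. On these data alone, whether acetyl, butanoyl or a longer chain carrying an amine on this carbonyl carbon would give an exact reading in this assay, and so show a direction for this position, also remains open.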